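The source may hold more compounds than are shown below. What is called first, only, known or untested is meant among the compounds shown, and "the series" means these compounds.

Three compounds share one core. Compound 1 `CCCCC(CC)Nc1nc(C)nc2c1nnn2-c1c(C)cc(C)cc1C` gives 7.6 nM in an in vitro assay on 293-EBNA cells for binding affinity to corticotropin-releasing factor receptor 1 (Homo sapiens); on this read-out lower numbers stand for stronger inhibition and higher numbers for weaker inhibition. Compound 3 `CCCCN(CC)c1nc(C)nc2c1nnn2-c1c(Cl)cc(OC)cc1OC` gives 4.4 nM in this assay. Compound 2 `COCC(COC)Nc1nc(C)nc2c1nnn2-c1ccc(C(C)C)cc1Br` gives 10.3 nM in this assay, the highest number of the three; its gap to compound 1 lies within the usual scatter of repeated measurements, while its gap to compound 3 lies beyond it. Compound 4 `CCCCC(CC)Nc1nc(C)nc2c1nnn2-c1ccc(C(C)C)cc1Br` has not yet been measured. It differs from compound 2 in one place: 1-ethylpentyl in place of 2-methoxy-1-(methoxymethyl)ethyl on a nitrogen on an aromatic ring. Going by the values given here, no measured pair isolates this exchange. Compound 1 carries this same entering group and gives 7.6 nM. On that basis, the step from compound 2 to compound 4 is expected to be a 1.5-fold lower number from compound 2 to compound 4 (0.17 log units; within the scatter), small, toward a lower number, and possibly not beyond the scatter. Compound 4 is estimated at 7 nM, within 3 nM to 17 nM.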

Compound 4, inhibition constant: 3.1 nM
Compound 4: the middle estimate sits 2.3-fold (0.35 log units) above what was measured; low and high end bracket the measured number.
By their numbers in this assay, from the lowest: compounds 4, 3, 1 and 2 (each within the scatter of the next, the first and the last beyond it).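

Going by these compounds alone, with nothing else changed, in this assay the swap of 2-methoxy-1-(methoxymethyl)ethyl for 1-ethylpentyl gives a 3.3-fold lower number from compound 2 to compound 4 (0.52 log units; beyond the scatter) as the first clean reading of this position. The oxygen atoms of the leaving group are thus not needed for a low number in this pair, and an all-carbon chain serves at least as well here. Nothing measured here explains why the number falls.

On these data alone, compound 1 and compound 3 have no one-place partner, so it stays open whether this step holds with other groups elsewhere on the shared core. As far as these compounds go, how a shorter chain, or a chain ending in an amine or a hydroxyl, would fare on this nitrogen also remains open.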